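Dimethylsulfamoyl for methylcarbamoyl on the amide-type nitrogen

The compounds below may be only part of what the source reports. "The series", "measured", "known", "first", "only" and "open" are said of these compounds alone.

In a functional assay on blood (Homo sapiens), with a stated time of 60 min, in the presence of a further agent that is not named here (on this read-out lower numbers stand for an effect already at smaller amounts and higher numbers for an effect only at larger amounts of compound), compound 1 (`O=C(OCc1ccccc1)C1(S(=O)(=O)c2ccc(Oc3ccc(OC(F)(F)F)cc3)cc2)CCC2(CCNCC2)C1`) gives > 15000 nM, a limit of the assay. Compound 2 (`CNC(=O)NC(=O)C1(S(=O)(=O)c2ccc(Oc3ccc(OC(F)(F)F)cc3)cc2)CCC2(CCNCC2)C1`) gives < 400 nM, also a limit. Among the measured compounds shown here, the one measured step, an at least 37-fold lower number from compound 1 to compound 2 (1.57 log units; beyond the scatter), is large and brings in (methylcarbamoyl)amino in place of benzyloxy on a carbonyl carbon. Compound 3 (`CN(C)S(=O)(=O)NC(=O)C1(S(=O)(=O)c2ccc(Oc3ccc(OC(F)(F)F)cc3)cc2)CCC2(CCNCC2)C1`) keeps the amide-type nitrogen but carries dimethylsulfamoyl in place of methylcarbamoyl, (dimethylsulfamoyl in place of methylcarbamoyl on an amide-type nitrogen). That measured step concerns another group and is only a loose guide. The expected change, a step that the limit leaves unreadable from compound 2 to compound 3, is estimated to stay within the scatter, with no direction favoured. Compound 3 is expected at 350 nM, with an estimated range of 70 nM to 1800 nM.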

Compound 3, half-maximal effective concentration: > 15000 nM
Compound 3: a limit, no number; the forecaster's own chance of this, stated with the estimate: 35%; at least 42-fold (1.63 log units) between middle value and limit.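

Compound 3 shows that an amide-type nitrogen at this place is not enough in itself: with dimethylsulfamoyl in place of methylcarbamoyl, this assay gives an at least 37-fold higher number from compound 2 to compound 3 (1.57 log units; beyond the scatter). What is carried on that nitrogen therefore decides the result, which compound 2 alone could not show. Compound 3 stands at a limit of the assay, and so does compound 1: the limit of > 15000 nM in this assay, at which 2 of the 3 values shown sit. The step between these two cannot be read.

From the compounds shown here alone, it remains open whether methylsulfamoyl or dimethylcarbamoyl on the same nitrogen would behave like compound 2 or like compound 3.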